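The source may report more compounds than this note shows. Statements on the series, on what has been measured and on what is new or still open speak of the compounds shown alone.

Compound 1 `CC1CCN(c2nc(Cl)nc3c2ncn3Cc2ccc(/C=C/C(=O)Nc3ccccc3N)cc2)CC1`: 26.9%
Compound 2 `Nc1ccccc1NC(=O)c1ccc(Cn2cnc3c(Nc4ccccc4)nc(Cl)nc32)cc1`: 83.5%
Compound 3 `Nc1ccccc1NC(=O)/C=C/c1ccc(Cn2cnc3c(NC4CCCCC4)nc(Cl)nc32)cc1`: 18.7%

In a functional assay on HCT-116 cells (Homo sapiens) for antiproliferative activity, read by CCK-8 assay, with a stated time of 72 h, tested at 8 uM (on this read-out lower numbers stand for a weaker effect and higher numbers for a stronger effect at the one concentration tested), compound 3 shows the lowest number of the three, though the step of a number 8.2 percentage points lower from compound 1 to compound 3 (within the scatter) lies within the scatter, so compound 1 is not separated from it; compound 2 stands far above both. Compound 4 `Nc1ccccc1NC(=O)/C=C/c1ccc(Cn2cnc3c(Nc4ccccc4)nc(Cl)nc32)cc1` arises from compound 3 by phenyl in place of cyclohexyl on a nitrogen on an aromatic ring. For the measured compounds named here, no measured step makes this same exchange; the one measured step, from compound 1 to compound 3, swaps one saturated ring for another and stays within the scatter. Compound 2 carries the anilino group with a different linker and gives 83.5%. On that basis compound 4 is expected to rise by a number 31.3 percentage points higher from compound 3 to compound 4 (beyond the scatter), with wide uncertainty. Compound 4 is therefore estimated at 50%, between 20% and 85%.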

Compound 4, a percentage reported as inhibition, at one concentration (the size of the read-out at that concentration, not a potency): 30.9%
Estimate against measurement, compound 4: 19.1 percentage points above; the measured number falls inside the stated range.
By their numbers in this assay, from the lowest: compounds 3, 1 and 4 (each within the scatter of the next, the first and the last beyond it); then compound 2.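

In this assay, phenyl in place of cyclohexyl on a nitrogen on an aromatic ring gives a number 12.2 percentage points higher from compound 3 to compound 4 (beyond the scatter), whereas anilino in place of 4-methylpiperidin-1-yl on an aromatic carbon gives a number 4 percentage points higher from compound 1 to compound 4 (within the scatter). With anilino held constant, 2-((2-aminophenyl)carbamoyl)ethenyl in place of (2-aminophenyl)carbamoyl gives a number 52.6 percentage points lower from compound 2 to compound 4 (beyond the scatter), so anilino alone does not secure the high number of compound 2. No available evidence explains these steps.

From the compounds shown here alone, whether (2-aminophenyl)carbamoyl would raise the numbers with cyclohexylamino or 4-methylpiperidin-1-yl remains open. So does the effect of benzylamino or morpholin-4-yl in place of anilino on that aromatic carbon.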